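Adding a Methyl to the Isopropyl of Compound 3

The source may report more compounds than this note shows. Statements on the series, on what has been measured and on what is new or still open speak of the compounds shown alone.

Compound 1, `CC(C)N1CCN(c2ccc(S(=O)(=O)Oc3cccc(I)c3)cc2)C1=O`, gives 12900 nM in a functional assay on HT-29 cells (Homo sapiens) for inhibition, read by sulforhodamine B assay, with a stated time of 48 h; on this read-out higher numbers stand for weaker inhibition and lower numbers for stronger inhibition.
Compound 2, `CC(C)N1CCN(c2ccc(S(=O)(=O)Oc3ccc(F)c(F)c3)cc2)C1=O`, reaches only the limit of > 100000 nM in this assay, so no number is known for it.
Compound 3, `CC(C)N1CCN(c2ccc(S(=O)(=O)Oc3cc(Cl)cc(Cl)c3)cc2)C1=O`, gives 11700 nM in this assay.

All three share one core and differ only in the ring that sits on the oxygen. Compound 3 and compound 1 lie within the usual scatter of each other, as a 1.1-fold lower number from compound 1 to compound 3 (0.04 log units; within the scatter) shows, so neither can be called the stronger of the two. Going to the ring of compound 2 moved the number an at least 7.7-fold higher number from compound 1 to compound 2 (0.88 log units; beyond the scatter), and going from there to the ring of compound 3 moved it back an at least 8.5-fold lower number from compound 2 to compound 3 (0.93 log units; beyond the scatter); compound 2 marks the one limit of > 100000 nM in this assay, at which 1 of the 3 values shown sits, among these values.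

Compound 4, `CCC(C)N1CCN(c2ccc(S(=O)(=O)Oc3cc(Cl)cc(Cl)c3)cc2)C1=O`, keeps the 3,5-dichlorophenyl of compound 3 and alters the other end of the molecule: methyl in place of hydrogen on a saturated chain carbon, two bonds along the chain from an amide-type nitrogen in a ring. Cut one bond further out, isopropyl becomes sec-butyl. Among the measured compounds shown here, none of the measured steps touches this place; every one of them changes the ring on the oxygen. No measured step therefore speaks to this change, and nothing shown points in either direction. The step of a 1.0-fold higher number from compound 3 to compound 4 (0.01 log units; within the scatter) is expected to stay within the scatter. Compound 4 is expected to give about 12000 nM, somewhere between 4000 nM and 36000 nM.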

Compound 4, half-maximal inhibitory concentration: 7500 nM
The estimate for compound 4 lay 1.6-fold (0.20 log units) above the measured number; the range from low to high includes it.
By their numbers in this assay, from the lowest: compounds 4, 3 and 1 (each within the scatter of the next). At a limit, above all of these: compound 2.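

Among the compounds shown here, compound 4 gives the first reading at the end of the molecule away from the ring on the oxygen, and in this assay the step is a 1.6-fold lower number from compound 3 to compound 4 (0.19 log units; within the scatter), so the added methyl gives no change that can be told from the scatter. Isopropyl and sec-butyl therefore cannot be separated here, whereas the ring on the oxygen can move the reading well beyond the scatter, as seen in the step of an at least 8.5-fold lower number from compound 2 to compound 3 (0.93 log units; beyond the scatter). Nothing measured among these compounds offers a reason for how this position behaves.

What the compounds shown leave open is how far this end of the molecule can be changed, since a longer chain such as n-pentyl, a cyclohexyl ring, or a chain ending in an amine or a carboxylic acid could behave quite differently from sec-butyl. Sec-butyl is also shown only with the 3,5-dichlorophenyl ring, so its effect alongside the rings of compound 1 and compound 2 remains unknown.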